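This account rests on a few compounds, and the source may have more. Where it says the series, first, only, none or still open, it means among the compounds named here.

Compound 1, `CC(C)[C@@H]1CC[C@@H](C)C[C@@]12N(C)C(=O)[C@@H]1[C@H]3C(=O)NC(=O)[C@H]3ON12`, is the starting point. Among the measured compounds shown here, in a functional assay, with a stated time of 20 min (a lower number here means a stronger inhibitor, a higher number a weaker inhibitor), compound 1 gives 1550 ug/mL, one of only two numbers measured so far. The other belongs to compound 2, `CC(C)[C@@H]1CC[C@@H](C)C[C@@]12N(C)C(=O)[C@@H]1[C@H]3C(=O)N(c4ccc(Cl)cc4)C(=O)[C@H]3ON12`, which in this assay gives 2150 ug/mL, so the two stand close together and their gap is within the scatter. The step between them is a 1.4-fold higher number from compound 1 to compound 2 (0.14 log units; within the scatter), where 4-chlorophenyl replaced hydrogen on an amide-type nitrogen in a ring.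

Compound 3, `Cc1ccc(N2C(=O)[C@H]3[C@H](ON4[C@@H]3C(=O)N(C)[C@@]43C[C@H](C)CC[C@H]3C(C)C)C2=O)c(C)c1`, has not been measured. It differs from compound 1 by 2,4-dimethylphenyl in place of hydrogen on an amide-type nitrogen in a ring. For the measured compounds named here, the only measured step of the same kind, a 1.4-fold higher number from compound 1 to compound 2 (0.14 log units; within the scatter), placed a different aryl group at the same position and stayed within the scatter, so no step beyond the scatter is expected here either. Compound 3 is therefore estimated at 1900 ug/mL in this assay, with a range from 900 ug/mL to 4000 ug/mL, which as a step means an expected 1.2-fold higher number from compound 1 to compound 3 (0.09 log units; within the scatter).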

Compound 3, half-maximal inhibitory concentration: 500 ug/mL
Compound 3: the middle estimate sits 3.8-fold (0.58 log units) above what was measured; the measured number lies below the stated range.
By their numbers in this assay, from the lowest: compound 3; then compounds 1 and 2 (each within the scatter of the next).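

The amide-type nitrogen in a ring is not a place where every aryl group leaves the number unchanged. In this assay there is a 3.1-fold lower number from compound 1 to compound 3 (0.49 log units; beyond the scatter) with 2,4-dimethylphenyl in place of hydrogen, while 4-chlorophenyl at the same nitrogen stayed within the scatter of the hydrogen compound. The direct exchange of the two aryl groups gives a 4.3-fold lower number from compound 2 to compound 3 (0.63 log units; beyond the scatter) and so shows that the choice of aryl group matters here, not merely the presence of one.

The compounds shown leave open whether both methyl groups are needed or only one of them, as a 2-methylphenyl or 4-methylphenyl group would show. They also leave open how a plain phenyl, an aminophenyl or a longer alkyl chain such as butyl would read at this nitrogen. Nothing available explains why the two aryl groups differ.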